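Turning the Single Stereocentre of Compound 2

The source may hold more compounds than are shown below. What is called first, only, known or untested is meant among the compounds shown, and "the series" means these compounds.

Compound 1 `O=C(CCCCCN1CCN(c2ccccc2-c2ccccc2)CC1)NCc1ccc(OCCO)cc1` has no reported result: in an assay on HEK293 cells for displacement of a labelled ligand from 5-hydroxytryptamine receptor 6 (Homo sapiens), read by scintillation counting, with a stated time of 1 h (on this read-out higher numbers stand for weaker inhibition and lower numbers for stronger inhibition), compound 1 gives "not determined" (no result reported). Among the compounds with values here, compound 2 `C[C@@H](NC(=O)CCCCCN1CCN(c2ccccc2-c2ccccc2)CC1)c1ccccc1` is therefore the only compound with a number: in this assay compound 2 gives 561 nM. Compound 3 `C[C@H](NC(=O)CCCCCN1CCN(c2ccccc2-c2ccccc2)CC1)c1ccccc1` has the same atoms and bonds as compound 2 and differs only in configuration: the two compounds have the same atoms and bonds and differ only in configuration as drawn: 1 of 1 stereo elements differ; a stereocentre at a saturated chain carbon is drawn R in compound 2 and S in compound 3. Within the data shown here, no pair of measured compounds shows how far such a change moves this assay, so the expected step of a 1.3-fold higher number from compound 2 to compound 3 (0.13 log units; within the scatter) is set near no change, with a wide band in either direction. On that basis compound 3 is estimated at 750 nM, between 150 nM and 3500 nM.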

Compound 3, inhibition constant: 480 nM
Compound 3: middle estimate off by 1.6-fold (0.19 log units), on the high side; measured number inside the range.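

In this assay, turning the stereocentre gives a 1.2-fold lower number from compound 2 to compound 3 (0.07 log units; within the scatter). Within the data shown here, this is the first measured reading for this change, and it shows that R and S at this saturated chain carbon cannot be told apart on this read-out. The comparison is a clean one, with a single difference between the two structures: the fact that compounds 2 and 3 differ only in the configuration as drawn

As far as these compounds go, it remains open whether configuration would stay this unimportant with an ethyl group or a carboxylic acid on this carbon. A single pair also cannot show whether the same holds with a longer chain.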